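This account rests on a few compounds, and the source may have more. Where it says the series, first, only, none or still open, it means among the compounds named here.

Measured in a functional assay on HL-60 cells (Homo sapiens) for antiproliferative activity, read by MTT assay; a lower number here means a stronger inhibitor, a higher number a weaker inhibitor:
- compound 1 `O[C@@H]1[C@@H](OCc2ccccc2)[C@H](OCc2ccccc2)[C@@H](COCc2ccccc2)O[C@@H]1CC1CCCCC1` - 17200 nM
- compound 2 `O[C@@H]1[C@@H](OCc2ccccc2)[C@H](OCc2ccccc2)[C@@H](COCc2ccccc2)O[C@@H]1Cc1ccccc1` - "not active" (no number reported)

Among the measured compounds shown here, compound 2 has no numerical value and is reported as "not active" (no number reported), so the series offers no measured step to scale from. The change to compound 3 `CC[C@H]1O[C@H](COCc2ccccc2)[C@@H](OCc2ccccc2)[C@H](OCc2ccccc2)[C@H]1O` is methyl in place of phenyl on a saturated chain carbon bound to a saturated ring carbon, which, cut one bond further out, reads benzyl to ethyl. In this assay, the expected step is small and of no firm direction, with weak activity or no number again. For the measured compounds named here, the only numerical anchor is compound 1 at 17200 nM. For compound 3 the estimated value is 30000 nM, with an expected range of 12000 nM to 80000 nM.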

Compound 3, half-maximal inhibitory concentration: "not active" (no number reported)
For compound 3 the study gives words and no number; the estimate stays without a comparison.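

Compound 2 and compound 3 are both reported as not active in this assay, in words without a number, so no step can be read between them. The compounds shown leave open how much activity, if any, either compound retains. No available evidence bears on this result.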